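The source may report more compounds than this note shows. Statements on the series, on what has been measured and on what is new or still open speak of the compounds shown alone.

Going by the values given here, compound 1, `CC(C)COC(=O)N1CCCc2cc(S(=O)(=O)N3CC(c4ccccc4)NC3=O)ccc21`, is one of two compounds measured in a functional assay on P388D1 cells (Mus musculus) for antiproliferative activity, read by MTT assay (on this read-out higher numbers stand for weaker inhibition and lower numbers for stronger inhibition), where compound 1 gives 1250 nM. Among the compounds with values here, its companion compound 2, `CCCCOC(=O)N1CCCc2cc(S(=O)(=O)N3CC(c4ccccc4)NC3=O)ccc21`, gives 2080 nM in this assay, and the one step between them, a 1.7-fold higher number from compound 1 to compound 2 (0.22 log units; within the scatter), arises from propyl in place of isopropyl on a saturated chain carbon bound to an oxygen next to a carbonyl group. Compound 1 therefore holds the lower of the two numbers, but the gap to compound 2 is within the scatter, so the two cannot be ordered.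

Compound 3, `O=C1NC(c2ccccc2)CN1S(=O)(=O)c1ccc2c(c1)CCCN2C(=O)C(F)(F)F`, differs from compound 1 by trifluoromethyl in place of isobutoxy on a carbonyl carbon, so the isobutoxycarbonyl of compound 1 becomes a (trifluoromethyl)carbonyl. Within the data shown here, the only measured step alters the chain on the oxygen side of that carbonyl and leaves the carbonyl-bound oxygen itself in place; it was small and within the scatter. Among the measured compounds shown here, no measured step exchanges an alkoxy group for a trifluoromethyl on this carbonyl carbon, so the data give no direct guide. The step from compound 1 to compound 3 is expected to be a 1.8-fold higher number from compound 1 to compound 3 (0.25 log units; within the scatter), with wide uncertainty. Compound 3 is estimated at 2200 nM, within 600 nM to 8000 nM.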

Compound 3, half-maximal inhibitory concentration: 4720 nM
Compound 3: the middle estimate sits 2.1-fold (0.33 log units) below what was measured; the measured number falls inside the stated range.
By their numbers in this assay, from the lowest: compounds 1 and 2 (each within the scatter of the next); then compound 3.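

In this assay, the carbonyl carbon proves sensitive to what is bound to it: trifluoromethyl in place of isobutoxy gives a 3.8-fold higher number from compound 1 to compound 3 (0.58 log units; beyond the scatter), and trifluoromethyl in place of butoxy gives a 2.3-fold higher number from compound 2 to compound 3 (0.36 log units; beyond the scatter). Both steps lie beyond the scatter and point the same way, towards weaker inhibition, whereas the earlier exchange of one alkoxy chain for another could not separate compound 1 from compound 2, so this position tolerates that small change in the chain but responds to replacing the whole alkoxy group. No evidence at hand bears on what lies behind this shift.

On these data alone, what a methyl or a longer alkyl chain on this carbonyl carbon would give remains open, and with it whether the higher number goes with the loss of the oxygen or with the arrival of the fluorine atoms. Also open, as far as these compounds go, is how an amine on the same carbon, or a much shorter alkoxy group such as methoxy, would compare with compound 1 and compound 3.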